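From cyclopropyl to 4-fluorophenyl on a triple-bonded carbon

The compounds below may be only part of what the source reports. "The series", "measured", "known", "first", "only" and "open" are said of these compounds alone.

Values in a functional assay on HCT-116 cells (Homo sapiens) for antiproliferative activity, with a stated time of 72 h (on this read-out lower numbers stand for stronger inhibition and higher numbers for weaker inhibition), are as follows.
Compound 1 `CCCC#Cc1cc([C@@H]2O[C@H](CO)[C@@H](O)[C@H]2O)n2ncnc(N)c12` gives 200 nM
Compound 2 `CCCCC#Cc1cc([C@@H]2O[C@H](CO)[C@@H](O)[C@H]2O)n2ncnc(N)c12` gives 2900 nM
Compound 3 `Nc1ncnn2c([C@@H]3O[C@H](CO)[C@@H](O)[C@H]3O)cc(C#CC3CC3)c12` gives 50 nM

The lowest number of the three belongs to compound 3. Swapping propyl for cyclopropyl gave a 4.0-fold lower number from compound 1 to compound 3 (0.60 log units; beyond the scatter) and that step is modest, while swapping butyl for cyclopropyl gave a 58-fold lower number from compound 2 to compound 3 (1.76 log units; beyond the scatter) and that step is large.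

Compound 4 `Nc1ncnn2c([C@@H]3O[C@H](CO)[C@@H](O)[C@H]3O)cc(C#Cc3ccc(F)cc3)c12` has not been measured. It carries 4-fluorophenyl in place of cyclopropyl on a triple-bonded carbon and so changes the same spot as every measured step. The closest warning comes from lengthening the chain by a single methyl, which gave a 15-fold higher number from compound 1 to compound 2 (1.16 log units; beyond the scatter) and shows how sensitive this spot can be. Going by the values given here, no measured compound has an aromatic ring here, so this guide is loose. A large step towards weaker inhibition is expected in this assay with wide uncertainty. The estimated change is a 10-fold higher number from compound 3 to compound 4 (1.00 log units; beyond the scatter) and it could prove smaller. For compound 4 the expected value is 500 nM within an estimated range from 70 nM to 4000 nM overall.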

Compound 4, half-maximal inhibitory concentration: > 100000 nM
Compound 4: a limit, no number (the forecaster's own chance of this, stated with the estimate: 5%); middle value at least 200-fold (2.30 log units) away from the limit.
By their numbers in this assay, from the lowest: compound 3; then compound 1; then compound 2. At a limit, above all of these: compound 4.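

In this assay, compound 4 gives a limit of the assay and not a number: the limit of > 100000 nM in this assay, at which 1 of the 4 values shown sits. With 4-fluorophenyl on the triple-bonded carbon, the comparisons are an at least 2000-fold higher number from compound 3 to compound 4 (3.30 log units; beyond the scatter), an at least 500-fold higher number from compound 1 to compound 4 (2.69 log units; beyond the scatter) and an at least 34-fold higher number from compound 2 to compound 4 (1.53 log units; beyond the scatter), all of them large. The earlier compounds carried only saturated groups at this spot, and even compound 2, with butyl, still gave a measurable 2900 nM, so compound 4 is the first shown where an aromatic ring stands here and the first to leave the measurable range.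

On these data alone, it remains open whether this loss belongs to the ring itself or to its fluorine. A plain phenyl, a pyridine ring or a short chain ending in an amine at the same spot would help to separate these possibilities.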